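Removing the Last Methoxy: What to Expect of Compound 4

The source may hold more compounds than are shown below. What is called first, only, known or untested is meant among the compounds shown, and "the series" means these compounds.

Of the compounds shown here, three that share one core have been tested in a functional assay on NCI-H460 cells (Homo sapiens) for antiproliferative activity, with a stated time of 72 h; a lower number here means a stronger inhibitor, a higher number a weaker inhibitor. Compound 1 `C=CC[C@H]1C[C@]2([C@@H](C)Cc3ccc(OC)c(OC)c3)OCOC2=CC1=O` gives 260 nM. Compound 2 `C=CC[C@H]1C[C@]2([C@@H](C)Cc3ccc(OC)cc3)OCOC2=CC1=O` gives 90 nM, and compound 3 `C=CC[C@H]1C[C@]2([C@H](C)Cc3ccc(OC)cc3)OCOC2=CC1=O` gives 120 nM. Compound 2 thus carries the lowest of the three numbers; compound 3 sits within the usual scatter of it, while the step of a 2.9-fold lower number from compound 1 to compound 2 (0.46 log units; beyond the scatter) lies beyond that scatter. The closeness of compounds 2 and 3 goes with the fact that compounds 2 and 3 differ only in the configuration as drawn, and the step of a 1.3-fold higher number from compound 2 to compound 3 (0.12 log units; within the scatter) stays within the scatter.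

Compound 4 `C=CC[C@H]1C[C@]2([C@@H](C)Cc3ccccc3)OCOC2=CC1=O` has not yet been measured. Relative to compound 2 the change is hydrogen in place of methoxy on an aromatic carbon. Of the measured steps, only a 2.9-fold lower number from compound 1 to compound 2 (0.46 log units; beyond the scatter) is of the same kind, hydrogen in place of methoxy on an aromatic carbon, and it gave a lower number; the configurational step between compounds 2 and 3 says nothing about this change. On that single precedent, a modest lowering is expected for compound 4 in this assay, estimated as a 1.4-fold lower number from compound 2 to compound 4 (0.14 log units; within the scatter). For compound 4 the expected value is 65 nM, with a range from 25 nM to 220 nM.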

Compound 4, half-maximal inhibitory concentration: 9700 nM
Estimate against measurement, compound 4: 150-fold (2.17 log units) below; the whole stated range lies below it.
By their numbers in this assay, from the lowest: compounds 2 and 3 (each within the scatter of the next); then compound 1; then compound 4.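

The step of a 110-fold higher number from compound 2 to compound 4 (2.03 log units; beyond the scatter) shows that in this assay the methoxy para to a large group carries far more weight than the earlier precedent suggested. The same kind of change, hydrogen in place of methoxy on an aromatic carbon, gave the opposite direction and a much smaller size in the step of a 2.9-fold lower number from compound 1 to compound 2 (0.46 log units; beyond the scatter), so its outcome on this series depends on which methoxy leaves. Nothing given here accounts for the size of this loss on going from 4-methoxyphenyl to phenyl.

The compounds shown leave open whether another group at this place, such as ethoxy, hydroxy, fluorine or an amine, would keep the number close to that of compound 2. They also leave open whether the opposite chain configuration of compound 3 would suffer the same loss with a plain phenyl.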